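Thiosemicarbazone series: aryl swap on the amide-type nitrogen

The source may report more compounds than this note shows. Statements on the series, on what has been measured and on what is new or still open speak of the compounds shown alone.

Measured so far in a functional assay on HT-29 cells (Homo sapiens) for antiproliferative activity, read by sulforhodamine B assay, with a stated time of 72 h; on this read-out lower numbers stand for stronger inhibition and higher numbers for weaker inhibition:
- compound 1 `Fc1cccc(NC(=S)N/N=C/c2ccc3ccccc3n2)c1`: 74700 nM
- compound 2 `NC(=S)N/N=C/c1cc2ccccc2s1`: 99200 nM

Compound 1 sits within the scatter of compound 2 on these numbers; the two are not separated. Among the compounds with values here, no step between measured compounds is at hand, so the aryl swap has no precedent here.

Compound 3 `Cc1ccccc1NC(=S)N/N=C/c1ccc2ccccc2n1` differs from compound 1 by 2-methylphenyl in place of 3-fluorophenyl on an amide-type nitrogen. With nothing in the data to point either way, the expected step of a 1.1-fold lower number from compound 1 to compound 3 (0.03 log units; within the scatter) in this assay is none beyond the scatter. Compound 3 is therefore estimated at 70000 nM, with a range from 25000 nM to 200000 nM.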

Compound 3, half-maximal inhibitory concentration: 42300 nM
The estimate for compound 3 lay 1.7-fold (0.22 log units) above the measured number, within the range that was stated.
By their numbers in this assay, from the lowest: compounds 3, 1 and 2 (each within the scatter of the next, the first and the last beyond it).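

Within the data shown here, on the amide-type nitrogen, 2-methylphenyl in place of 3-fluorophenyl gives a 1.8-fold lower number from compound 1 to compound 3 (0.25 log units; within the scatter) in this assay and is the first step read at this position. The two aryl groups are not separated on this read-out, so this position tolerates the exchange of one for the other, with the shared core unchanged. No data at hand bear on this result.

Still open, going by these compounds, is whether a larger change at this nitrogen, such as a longer alkyl chain, or a phenyl carrying a carboxylic acid or an amine, would give a step beyond the scatter.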